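This account rests on a few compounds, and the source may have more. Where it says the series, first, only, none or still open, it means among the compounds named here.

Measured compounds:
compound 1, `ClCc1cccc(Cn2cnc3c(Cl)nc(Cl)nc32)c1` — 20400 nM
compound 2, `Nc1nc(Cl)c2ncn(Cc3ccccc3CCl)c2n1` — 39800 nM

Of the compounds shown here, two sharing one fused core have been measured in a functional assay on OVCAR-5 cells (Homo sapiens) for cytotoxicity, read by sulforhodamine B assay, with a stated time of 48 h; a lower number here means a stronger inhibitor of growth, a higher number a weaker inhibitor of growth. Compound 1 `ClCc1cccc(Cn2cnc3c(Cl)nc(Cl)nc32)c1` gives 20400 nM in this assay. Compound 2 `Nc1nc(Cl)c2ncn(Cc3ccccc3CCl)c2n1` gives 39800 nM in this assay. Compound 1 carries the lower of the two numbers, but the gap to compound 2 lies within the scatter, so the two cannot be placed in order on this evidence.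

Compound 3 `ClCc1cccc(Cn2cnc3c(Cl)ncnc32)c1` has not yet been measured. It differs from compound 1 in one place: hydrogen in place of chloro on an aromatic carbon. The site of the change is an aromatic carbon between two ring nitrogen atoms of the core, and a chloro group remains elsewhere on the same ring.

Among the compounds with values here, no step between measured compounds that differ in one place exists here, so the weight of this change is unknown. The author's expectation is that it costs little: compound 3 is estimated at 30000 nM in this assay, within 8000 nM to 100000 nM, a step of a 1.5-fold higher number from compound 1 to compound 3 (0.17 log units; within the scatter) that is expected to stay within the scatter.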

Compound 3, concentration for total growth inhibition: 4360 nM
The estimate for compound 3 lay 6.9-fold (0.84 log units) above the measured number, and the stated range ends above it.
By their numbers in this assay, from the lowest: compound 3; then compounds 1 and 2 (each within the scatter of the next).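

In this assay, hydrogen in place of chloro on the aromatic carbon between two ring nitrogen atoms gives a 4.7-fold lower number from compound 1 to compound 3 (0.67 log units; beyond the scatter), so this change moves the number beyond the scatter and towards stronger inhibition of growth. Within the data shown here, this is the first reading of any single change on the shared core, and it shows that a chloro group at this position is not needed for growth inhibition in this assay, with compound 3 keeping the chloro group meta to the site. Nothing available accounts for the size or direction of this step.

The compounds shown leave open whether hydrogen is the best choice at this carbon, or whether a fluoro, methyl or methoxy group there would give a lower or higher number than compound 3 does. As far as these compounds go, it also remains open whether the same step would appear with the chloromethyl group placed as in compound 2, which differs from compound 3 in more than one place and so cannot be compared with it directly.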